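The source may report more compounds than this note shows. Statements on the series, on what has been measured and on what is new or still open speak of the compounds shown alone.

Compound 1 `O=C(NNC(=O)c1ccccc1F)c1ccc(NS(=O)(=O)c2cnc(O)nc2O)cc1` and compound 3 `O=C(NNC(=O)c1ccccc1F)c1cccc(NS(=O)(=O)c2cnc(O)nc2O)c1` share a hydrazide built on a (2-fluorophenyl)carbonyl group, and the difference between their two cores is not broken down here. In a functional assay on OVCAR-3 cells (Homo sapiens) for antiproliferative activity, read by MTT assay, with a stated time of 24 h (on this read-out lower numbers stand for stronger inhibition and higher numbers for weaker inhibition), compound 1 gives 16000 nM, and compound 3 gives 10800 nM, the two numbers lying within the usual scatter of each other. Compound 2 `O=C(NNC(=O)c1ccc(NS(=O)(=O)c2cnc(O)nc2O)cc1)c1ccc(F)cc1` carries a 4-fluorophenyl in place of 2-fluorophenyl on a carbonyl carbon. Compound 2 gives > 20000 nM, which is a limit of this assay rather than a number (the limit of > 20000 nM in this assay, at which 1 of the 3 values shown sits). The step from compound 1 to compound 2 is therefore an at least 1.2-fold higher number from compound 1 to compound 2 (0.09 log units; that floor lies within the scatter), and it reaches the limit at which one of the three known values sits.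

Compound 4 `O=C(NNC(=O)c1cccc(NS(=O)(=O)c2cnc(O)nc2O)c1)c1ccc(F)cc1` makes the same change on the core of compound 3: 4-fluorophenyl in place of 2-fluorophenyl on a carbonyl carbon. From compound 3 to compound 4 a step of about a 1.6-fold higher number from compound 3 to compound 4 (0.20 log units; within the scatter) is expected, resting on the step from compound 1 to compound 2 an at least 1.2-fold higher number from compound 1 to compound 2 (0.09 log units; that floor lies within the scatter). Compound 4 is thus estimated at 17000 nM, within roughly 9000 nM to 40000 nM.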

Compound 4, half-maximal inhibitory concentration: > 20000 nM
Compound 4: a limit, no number; the forecaster's own chance of this, stated with the estimate: 35%; middle value at least 1.1-fold (0.07 log units) from the limit.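

In this assay compound 4 gives > 20000 nM, which is a limit of the assay and not a number. Carrying 4-fluorophenyl in place of 2-fluorophenyl on a carbonyl carbon over to this core gives an at least 1.8-fold higher number from compound 3 to compound 4 (0.26 log units; that floor lies within the scatter), and as on the core of compound 1, this is only a floor, so the two results fit a change that runs the same way on both cores but do not establish one. How large the change is on either core, and whether its size depends on the core, cannot be read from these values: the same change on two cores in this assay, an at least 1.2-fold higher number (0.09 log units; that floor lies within the scatter) from compound 1 to compound 2 and an at least 1.8-fold higher number (0.26 log units; that floor lies within the scatter) from compound 3 to compound 4; the limit leaves it open whether they differ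

The compounds shown leave open what other groups on the same carbonyl carbon would do, such as an unsubstituted phenyl, a chlorophenyl, a methoxyphenyl or a phenyl bearing a carboxylic acid. They also leave open how far compound 2 and compound 4 stand from their 2-fluorophenyl partners, as neither has a number in this assay.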